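This account rests on a few compounds, and the source may have more. Where it says the series, first, only, none or still open, it means among the compounds named here.

Series notes, this assay. In a functional assay on MCF7 cells (Homo sapiens) for antiproliferative activity, read by sulforhodamine B assay, with a stated time of 48 h (on this read-out lower numbers stand for stronger inhibition and higher numbers for weaker inhibition), compound 1 `CCc1ccc(NS(=O)(=O)c2ccc(N3CCNC3=O)cc2)cc1` gives 810 nM, compound 2 `Cc1ccccc1NS(=O)(=O)c1ccc(N2CCNC2=O)cc1` gives 280 nM, and compound 3 `O=C1NCCN1c1ccc(S(=O)(=O)Nc2ccc(Cl)cc2)cc1` gives 170 nM. Compound 2 stands second highest of the three numbers; nearest is compound 3 through the step of a 1.6-fold lower number from compound 2 to compound 3 (0.22 log units; within the scatter), furthest is compound 1 through the step of a 2.9-fold lower number from compound 1 to compound 2 (0.46 log units; beyond the scatter). Compound 4 `Cc1ccc(NS(=O)(=O)c2ccc(N3CCNC3=O)cc2)cc1` is not yet measured; the change from compound 2 is 4-methylphenyl in place of 2-methylphenyl on a sulfonamide nitrogen. Both measured steps on the sulfonamide nitrogen bear on it: a 2.9-fold lower number from compound 1 to compound 2 (0.46 log units; beyond the scatter) and a 1.6-fold lower number from compound 2 to compound 3 (0.22 log units; within the scatter), with 4-ethylphenyl and 4-chlorophenyl flanking 2-methylphenyl on either side. No step beyond the scatter is therefore expected; compound 4 is estimated at 400 nM, range 150 nM to 1000 nM, a step of a 1.4-fold higher number from compound 2 to compound 4 (0.15 log units; within the scatter).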

Compound 4, half-maximal inhibitory concentration: 610 nM
Compound 4: middle estimate off by 1.5-fold (0.18 log units), on the low side; measured number inside the range.
By their numbers in this assay, from the lowest: compounds 3 and 2 (each within the scatter of the next); then compounds 4 and 1 (each within the scatter of the next).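

In this assay, 4-methylphenyl in place of 2-methylphenyl on a sulfonamide nitrogen gives a 2.2-fold higher number from compound 2 to compound 4 (0.34 log units; beyond the scatter), so with the same atoms the way they are joined matters at this position. The 4-methylphenyl and 4-ethylphenyl groups do not separate, a 1.3-fold lower number from compound 1 to compound 4 (0.12 log units; within the scatter), whereas methyl in place of chloro on an aromatic carbon gives a 3.6-fold higher number from compound 3 to compound 4 (0.55 log units; beyond the scatter). Nothing available accounts for these steps.

Open: how a methoxy group, an amine or a carboxylic acid would read in place of that methyl, and whether the difference between 2-methylphenyl and 4-methylphenyl recurs with chloro or ethyl.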